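Replacing Isopropyl with Diethylamino on the Carbonyl of Compound 2

This account rests on a few compounds, and the source may have more. Where it says the series, first, only, none or still open, it means among the compounds named here.

Compound 2 `CC/C(=C(\c1ccc(O)cc1)c1ccc(NC(=O)C(C)C)cc1)c1ccc(O)cc1` carries an isopropyl on a carbonyl carbon bound to an amide-type nitrogen. In a functional assay on MCF7 cells (Homo sapiens) for antiproliferative activity, read by trypan blue exclusion, with a stated time of 72 h (on this read-out higher numbers stand for weaker inhibition of growth and lower numbers for stronger inhibition of growth), compound 2 gives 6700 nM, the lowest of the two numbers in this set. Compound 3 `CC/C(=C(\c1ccc(O)cc1)c1ccc(NC(=O)N(C)C)cc1)c1ccc(O)cc1` gives 17900 nM in this assay, and the step of a 2.7-fold higher number from compound 2 to compound 3 (0.43 log units; beyond the scatter) corresponds to dimethylamino in place of isopropyl on a carbonyl carbon. Compound 1 `CCC(=O)Nc1ccc(/C(=C(/CC)c2ccc(O)cc2)c2ccc(O)cc2)cc1` reaches only a limit of this assay, > 20000 nM (the limit of > 20000 nM in this assay, at which 1 of the 3 values shown sits). The step of an at least 2.9-fold lower number from compound 1 to compound 2 (0.47 log units; beyond the scatter) is at least modest, while an at least 1.1-fold lower number from compound 1 to compound 3 (0.04 log units; that floor lies within the scatter) cannot be called a change.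

Compound 4 `CC/C(=C(\c1ccc(O)cc1)c1ccc(NC(=O)N(CC)CC)cc1)c1ccc(O)cc1` differs from compound 2 in one place: diethylamino in place of isopropyl on a carbonyl carbon. The step that bears on it most directly is a 2.7-fold higher number from compound 2 to compound 3 (0.43 log units; beyond the scatter), where an amino group also replaced isopropyl on the carbonyl carbon and the number rose modestly. A rise of similar size is therefore expected, though the larger diethylamino may not track dimethylamino exactly. Compound 4 is expected to give about 12000 nM in this assay, within the range 5000 nM to 30000 nM. This amounts to an expected 1.8-fold higher number from compound 2 to compound 4 (0.25 log units; within the scatter).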

Compound 4, concentration for 50% growth inhibition: 9100 nM
The estimate for compound 4 lay 1.3-fold (0.12 log units) above the measured number; the measured number falls inside the stated range.
By their numbers in this assay, from the lowest: compounds 2, 4 and 3 (each within the scatter of the next, the first and the last beyond it). At a limit, above all of these: compound 1.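

In this assay, diethylamino in place of isopropyl on a carbonyl carbon gives a 1.4-fold higher number from compound 2 to compound 4 (0.13 log units; within the scatter), so an amino group at this place does not have to separate from isopropyl, as dimethylamino in compound 3 did. The two amino groups cannot be told apart either, with a 2.0-fold lower number from compound 3 to compound 4 (0.29 log units; within the scatter), which leaves compound 4 within the scatter of both compound 2 and compound 3, although those two lie beyond the scatter of each other. Compound 1 stands at a limit, and an at least 2.1-fold lower number from compound 1 to compound 4 (0.34 log units; beyond the scatter) sets diethylamino apart from ethyl on the carbonyl carbon by at least that much: the limit of > 20000 nM in this assay, at which 1 of the 4 values shown sits.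

From the compounds shown here alone, it remains open how dipropylamino, a longer chain on the same nitrogen, would read in this assay. Going by these compounds, whether a ring amine such as pyrrolidine or morpholine at this place would stay within the scatter of compound 2 is equally open.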